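Swapping the biphenyl arm for an aminophenyl in the FAAH series

The compounds below may be only part of what the source reports. "The series", "measured", "known", "first", "only" and "open" are said of these compounds alone.

The three measured compounds share one core, seen in compound 1 `COc1nn(Cc2ccccc2)c(=O)o1`, where a benzyl group hangs from the ring. In an assay on COS-7 cells for inhibition of Fatty-acid amide hydrolase 1 (Homo sapiens), read by scintillation counting, with a stated time of 10 min, tested at 10 uM (a lower number here means less inhibition, a higher number more inhibition at the concentration tested (going by the name of the read-out)), compound 1 gives "not active" (no number reported). Compound 2 `COc1nn(Cc2ccccc2-c2ccccc2)c(=O)o1` carries a second phenyl on that benzyl ring, and in this assay compound 2 gives 23%. Compound 3 `COc1nn(Cc2cccc3ccccc23)c(=O)o1` instead fuses a second ring onto the benzyl ring, and in this assay compound 3 gives 35%. Of the two numbers, compound 2 is the lower one, and compound 3 stands above it by more than the usual scatter, while compound 1 returned no number at all.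

Compound 4 `COc1nn(Cc2ccccc2N)c(=O)o1` is not yet measured. It differs from compound 2 in one spot: amino in place of phenyl on an aromatic carbon. Among the measured compounds shown here, no pair of measured compounds shows this exact change, so the step can only be judged from the pattern that a larger group on the benzyl ring, as in compound 2 and compound 3, goes with a measurable number, whereas the bare benzyl of compound 1 does not. Because compound 1 gives "not active" (no number reported), a return toward a small substituent is expected to lower the inhibition in this assay, and the step of a number 13 percentage points lower from compound 2 to compound 4 (beyond the scatter) is expected to point downward. Compound 4 is therefore estimated at 10%, with a range from 0% to 28%.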

Compound 4, a percentage reported as inhibition, at one concentration (the size of the read-out at that concentration, not a potency): 8%
Beside the measured number, compound 4's estimate is 2 percentage points above it; the measured number falls inside the stated range.
By their numbers in this assay, from the lowest: compound 4; then compound 2; then compound 3.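

In this assay, among the compounds shown here, putting amino in place of phenyl on an aromatic carbon of the six-membered aromatic ring gives a number 15 percentage points lower from compound 2 to compound 4 (beyond the scatter), the first step that can be read at this position. Even so, the small amino group does not bring the reading back to that of the unsubstituted parent: compound 4 gives 8% as a number, whereas compound 1 gives "not active" (no number reported) and no number at all. No measurement available here explains why the step goes downward.

This one swap changes several things at once, replacing 6 heavy atoms and a ring with 1 heavy atom and adding 1 hydrogen-bond donor and 1 hydrogen-bond acceptor, so it cannot show which of these changes matters for the reading. A methyl or a methoxy group at the same position, close in size to amino but different in its hydrogen-bonding counts, or a phenyl ring carrying its own amine, would be needed to pull those changes apart.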